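Dropping the Hydroxy Group from a Cyclohexylethoxy Analogue

The compounds below may be only part of what the source reports. "The series", "measured", "known", "first", "only" and "open" are said of these compounds alone.

Three compounds built on the same core have been examined in an ADME assay on Vero cells (Chlorocebus sabaeus) for cytotoxicity, read by sulforhodamine B assay, with a stated time of 72 h; on this read-out lower numbers stand for stronger inhibition and higher numbers for weaker inhibition. In this assay compound 1 `Cc1ccccc1COc1ccc2c(c1)[C@@H](O)CN(C)C2` shows only a limit, > 100000 nM. Compound 2 `CN1Cc2ccc(OCCC3CCCCC3)cc2[C@@H](O)C1` likewise gives only a limit in this assay, > 50000 nM. Compound 3 `CN1Cc2ccc(OCCCN3CCNCC3)cc2[C@@H](O)C1` also returns only a limit in this assay, > 100000 nM. Two of the three values therefore sit at the limit of > 100000 nM in this assay, at which 2 of the 3 values shown sit, and one at the limit of > 50000 nM in this assay, at which 1 of the 3 values shown sits, so compound 2 stands in no readable order against its neighbours. The measured steps that bear on the question are a step that the two limits leave unreadable from compound 1 to compound 2 and a step that the two limits leave unreadable from compound 2 to compound 3; neither has a readable size.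

Compound 4 `CN1CCc2cc(OCCC3CCCCC3)ccc2C1` differs from compound 2 by hydrogen in place of hydroxy on a saturated ring carbon. With both neighbouring steps unreadable, no shift beyond the scatter is expected in this assay. Compound 4 is thus estimated at 100000 nM, within 30000 nM to 300000 nM, most likely again reported as a limit. Relative to compound 2 the expected change, a step that the limit leaves unreadable from compound 2 to compound 4, is estimated to stay within the scatter.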

Compound 4, half-maximal inhibitory concentration: 25000 nM
Estimate against measurement, compound 4: 4.0-fold (0.60 log units) above, and the stated range ends above it.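

In this assay, within the data shown here, compound 4 gives 25000 nM, the only one of the four values shown that is a number and not a limit. Replacing the hydroxy on the saturated ring carbon with hydrogen gives an at least 2.0-fold lower number from compound 2 to compound 4 (0.30 log units; that floor lies within the scatter), so this is the one change shown that can be read at all, though only as a floor. Its true size stays unknown, because compound 2 carries only a limit: the limit of > 50000 nM in this assay, at which 1 of the 4 values shown sits.

Going by these compounds, whether a methoxy group or a fluorine on that same saturated ring carbon would read like the hydroxy of compound 2 or the hydrogen of compound 4 remains open. On these data alone, the steps linking compound 1, compound 2 and compound 3 cannot be read, so it also remains open how the chain on the oxygen bears on this read-out.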